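The source may report more compounds than this note shows. Statements on the series, on what has been measured and on what is new or still open speak of the compounds shown alone.

Among the compounds with values here, in a functional assay on CWR22R cells (Homo sapiens) for antiproliferative activity, read by propidium iodide staining, with a stated time of 96 h (on this read-out higher numbers stand for weaker inhibition and lower numbers for stronger inhibition), compound 1 `CC(O)(CS(=O)(=O)c1ccc(F)cc1)C(=O)Nc1ccc(S(F)(F)(F)(F)F)cc1` gives 20600 nM and compound 2 `CC(O)(CS(=O)(=O)c1ccc(C(F)(F)F)cc1)C(=O)Nc1ccc(S(F)(F)(F)(F)F)cc1` gives 28900 nM, so compound 2 stands within the scatter of the only other measured compound. Compound 3 `CC(O)(CS(=O)(=O)c1cccc(OC(F)(F)F)c1)C(=O)Nc1ccc(S(F)(F)(F)(F)F)cc1` carries 3-(trifluoromethoxy)phenyl in place of 4-(trifluoromethyl)phenyl on a sulfonyl sulfur. Within the data shown here, the one measured step, a 1.4-fold higher number from compound 1 to compound 2 (0.15 log units; within the scatter), also alters the group on the sulfonyl side, but it does not test this kind of change. No shift beyond the scatter is therefore expected in this assay. The expected step is a 1.2-fold lower number from compound 2 to compound 3 (0.08 log units; within the scatter). For compound 3 the estimated value is 24000 nM, with an expected range of 10000 nM to 55000 nM.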

Compound 3, half-maximal inhibitory concentration: 22400 nM
Beside the measured number, compound 3's estimate is 1.1-fold (0.03 log units) above it, and the stated range covers the measured number.
By their numbers in this assay, from the lowest: compounds 1, 3 and 2 (each within the scatter of the next).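

The change shows a 1.3-fold lower number from compound 2 to compound 3 (0.11 log units; within the scatter) in this assay and a 1.1-fold higher number from compound 1 to compound 3 (0.04 log units; within the scatter) when 3-(trifluoromethoxy)phenyl takes the place of 4-(trifluoromethyl)phenyl and of 4-fluorophenyl on a sulfonyl sulfur. All three aryl groups at this place now lie within the scatter of one another, including the one that brings a hydrogen-bond acceptor. No supporting data offer an account of this result.

Substituent identity and ring placement change together in these steps, so their separate contributions stay open. Also open, on these data alone, is how an amine or a carboxylic acid on this aromatic ring would read in this assay at this place.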